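The source may report more compounds than this note shows. Statements on the series, on what has been measured and on what is new or still open speak of the compounds shown alone.

Two members of the series have been run in an ADME assay on WI-38 cells (Homo sapiens) for inhibition, read by CellTiter-Glo, with a stated time of 4 days (on this read-out higher numbers stand for weaker inhibition of growth and lower numbers for stronger inhibition of growth), so far. Compound 1 `Clc1cc(-c2ccccc2)nn1-c1ccccn1` carries a chlorine and a pyridin-2-yl on the core. In this assay compound 1 returns only a limit, > 30000 nM. Compound 2 `Oc1cc(-c2ccccc2)nn1-c1ccccc1` carries a hydroxy group and a phenyl on the core. In this assay compound 2 likewise returns only a limit, > 30000 nM. Among the compounds with values here, compound 2 therefore stands at the edge of what has been measured: no true number of its own, and the single other value shown is a limit as well, (the limit of > 30000 nM in this assay, at which 2 of the 2 values shown sit). Within the data shown here, no step between measured compounds can be counted, as compounds 1 and 2 differ in more than one place.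

Compound 3 `Oc1cc(-c2ccccc2)nn1-c1ccncc1` is the next member, still to be measured in this assay. It differs from compound 2 by pyridin-4-yl in place of phenyl on an aromatic nitrogen. Among the measured compounds shown here, with both known values sitting at the limit, no measured step can guide the expectation; the working assumption is no change beyond the scatter. Compound 3 is expected to give 30000 nM, within a range of 12000 nM to 100000 nM. The step this estimate implies is a number no higher from compound 2 to compound 3 (the limit leaves the size open), most likely again reported only as a limit.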

Compound 3, concentration for 50% growth inhibition: > 30000 nM
Compound 3 ended at the assay's limit; the forecaster's own chance of this, stated with the estimate: 80%; the middle value lies on the limit itself.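

No step can be read from compound 2 to compound 3 in this assay, as both values are limits: the limit of > 30000 nM in this assay, at which 3 of the 3 values shown sit.

The compounds shown leave open whether any member of the series gives a true value in this assay, and so what pyridin-4-yl in place of phenyl on an aromatic nitrogen does to growth inhibition.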